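Chloro for hydrogen, carried to a second core

This account rests on a few compounds, and the source may have more. Where it says the series, first, only, none or still open, it means among the compounds named here.

Three compounds have been measured in a functional assay on MCF7 cells (Homo sapiens) for cytotoxicity, read by sulforhodamine B assay, with a stated time of 72 h; on this read-out higher numbers stand for weaker inhibition and lower numbers for stronger inhibition:

Compound 1, `O=C(Nc1ccc(Nc2ncnc3c2cnn3-c2ccccc2)cc1)Nc1ccccc1Cl`: 55100 nM
Compound 2, `O=C(Nc1ccc(Nc2ncnc3c2cnn3-c2ccc(Cl)cc2)cc1)Nc1ccccc1Cl`: 9050 nM
Compound 3, `Clc1ccc2nc(Nc3ncnc4c3cnn4-c3ccccc3)sc2c1`: > 100000 nM, which is a limit of the assay and not a number.

The step from compound 1 to compound 2 is a 6.1-fold lower number from compound 1 to compound 2 (0.78 log units; beyond the scatter); the change is chloro in place of hydrogen on an aromatic carbon. For compound 3 only a limit is known: the limit of > 100000 nM in this assay, at which 1 of the 3 values shown sits. How the core of compound 3 differs from the core of compound 1 is not broken down here.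

Compound 4, `Clc1ccc(-n2ncc3c(Nc4nc5ccc(Cl)cc5s4)ncnc32)cc1`, has not yet been measured. It differs from compound 3 by chloro in place of hydrogen on an aromatic carbon, the same change, at the same place, as that from compound 1 to compound 2. If that step carries over, compound 4 is expected to give a lower number than compound 3 by about an at least 1.6-fold lower number from compound 3 to compound 4 (0.22 log units; that floor lies within the scatter) in this assay, an expectation resting on a 6.1-fold lower number from compound 1 to compound 2 (0.78 log units; beyond the scatter). Since compound 3 gives only a limit, the starting point is uncertain, and compound 4 may itself return a limit. The estimate for compound 4 is 60000 nM, expected to fall between 15000 nM and 250000 nM.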

Compound 4, half-maximal inhibitory concentration: 85600 nM
Compound 4: the middle estimate sits 1.4-fold (0.15 log units) below what was measured; the range from low to high includes it.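

The chloro change now stands on two cores in this assay, and the two results compare as follows: the same change on two cores in this assay, a 6.1-fold lower number (0.78 log units; beyond the scatter) from compound 1 to compound 2 and an at least 1.1-fold lower number (0.06 log units; that floor lies within the scatter) from compound 3 to compound 4; the limit leaves it open whether they differ. On the core of compound 3 the change gives an at least 1.1-fold lower number from compound 3 to compound 4 (0.06 log units; that floor lies within the scatter) and this floor fits a step as large as the first one, but it fits a very small step equally well. Whether the step carries over at its full size is therefore not shown, for compound 3 gives a limit of the assay and not a number: the limit of > 100000 nM in this assay, at which 1 of the 4 values shown sits.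

The compounds shown hold only hydrogen or chloro at this place on the phenyl ring, so it stays open whether a fluoro, a methyl or a methoxy group there would give a similar step. On these data alone, it also stays open how the change behaves on a further core whose parent compound gives a number rather than a limit, and whether an amine or a carboxylic acid on the ring would move the values.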